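The source may hold more compounds than are shown below. What is called first, only, known or untested is meant among the compounds shown, and "the series" means these compounds.

Compound 1 `CC/C=C\[C@H](C)[C@H](OC(N)=O)[C@@H](C)[C@H](O)[C@@H](C)C/C(C)=C\[C@H](C)[C@@H](O)[C@@H](C)/C=C\[C@@H](O)C[C@@H]1OC(=O)[C@H](C)[C@@H](O)[C@H]1C`: "not determined" (no result reported) in a functional assay on A549 cells (Homo sapiens) for antiproliferative activity; a higher number here means a weaker inhibitor of growth, a lower number a stronger inhibitor of growth.
Compound 2 `CC/C=C\[C@H](C)[C@H](OC(N)=O)[C@@H](C)[C@H](O)[C@@H](C)C/C(C)=C\[C@H](C)[C@@H](O)[C@@H](C)/C=C\[C@@H](O)C[C@@H]1OC(=O)NC[C@H]1C`: 1000 nM in this assay.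

For the measured compounds named here, compound 2 holds the only number in this assay, so it has no measured neighbour to compare with. Compound 3 `CC/C=C\[C@H](C)[C@H](OC(N)=O)[C@@H](C)[C@H](O)[C@@H](C)C/C(C)=C\[C@H](C)[C@@H](O)[C@@H](C)/C=C\[C@@H](O)C[C@H](O)[C@H](C)C[C@H](C)C(=O)OC` differs from compound 2 in one place: a group of 11 heavy atoms (8 carbon, 3 oxygen; no ring) in place of a group of 8 heavy atoms (5 carbon, 1 nitrogen, 2 oxygen; one six-membered non-aromatic ring with 2 hetero atoms), on a saturated chain carbon, two bonds along the chain from a double-bonded chain carbon and an oxygen on a saturated carbon. Without any measured step of this kind, the size and direction of the change are open; a loss of potency beyond the scatter is expected, but a small change cannot be excluded. Compound 3 is expected to give 3000 nM in this assay, within 500 nM to 20000 nM, a step of a 3.0-fold higher number from compound 2 to compound 3 (0.48 log units; beyond the scatter).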

Compound 3, concentration for 50% growth inhibition: 4000 nM
The estimate for compound 3 lay 1.3-fold (0.12 log units) below the measured number; the measured number falls inside the stated range.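

On this saturated chain carbon, replacing the six-membered non-aromatic ring with 2 hetero atoms by a group with no ring gives a 4.0-fold higher number from compound 2 to compound 3 (0.60 log units; beyond the scatter) in this assay. The ring is therefore not required for growth inhibition, although the ring-free compound 3 is the weaker of the pair, at 4000 nM. No measurement shown explains this step.

The compounds shown leave open which atoms of the changed group account for the step. Going by these compounds, it also remains unknown how a carboxylic acid or an amine would behave at this place.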